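The source may report more compounds than this note shows. Statements on the series, on what has been measured and on what is new or still open speak of the compounds shown alone.

Within the data shown here, in a functional assay on A2780 cells (Homo sapiens) for inhibition, read by sulforhodamine B assay, with a stated time of 96 h (on this read-out lower numbers stand for stronger inhibition of growth and higher numbers for weaker inhibition of growth), compound 1 (`CC[C@@H](Nc1nc(NCc2ccccn2)c2ncn(C(C)C)c2n1)C(C)(C)O`) gives 34000 nM and compound 2 (`CC[C@@H](Nc1nc(NCc2ccccn2)c2ncn(C(C)C)c2n1)C(C)O`) gives 15000 nM as the lowest number so far, the stronger growth inhibition of this pair. Compound 3 (`CCC(O)[C@H](CC)Nc1nc(NCc2ccccn2)c2ncn(C(C)C)c2n1`) is still to be measured. Its change from compound 2 is 1-ethyl-2-hydroxybutyl in place of 1-(1-hydroxyethyl)propyl on a nitrogen on an aromatic ring with the group sitting on a nitrogen on an aromatic ring.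

Among the measured compounds shown here, one measured step bears on this: a 2.3-fold lower number from compound 1 to compound 2 (0.36 log units; beyond the scatter) when hydrogen takes the place of methyl on a saturated chain carbon bound to an oxygen. Read backwards, that step links a larger group on this nitrogen with a higher number. For the measured compounds named here, compound 3 also carries the larger group, though built differently from the one in compound 1, and a single step is thin support. A step of similar or smaller size towards a higher number is therefore expected in this assay and it may not clear the scatter. The estimated move is a 1.7-fold higher number from compound 2 to compound 3 (0.24 log units; within the scatter) on this evidence. Compound 3 is expected at 26000 nM with an estimated range of 11000 nM to 55000 nM in this series.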

Compound 3, concentration for 50% growth inhibition: 21000 nM
Estimate against measurement, compound 3: 1.2-fold (0.09 log units) above; low and high end bracket the measured number.
By their numbers in this assay, from the lowest: compounds 2, 3 and 1 (each within the scatter of the next, the first and the last beyond it).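

In this assay, 1-ethyl-2-hydroxybutyl in place of 1-(1-hydroxyethyl)propyl on a nitrogen on an aromatic ring gives a 1.4-fold higher number from compound 2 to compound 3 (0.15 log units; within the scatter), so this position accepts the change of chain without a readable shift in growth inhibition. Set against the tertiary alcohol side chain, the same group gives a 1.6-fold lower number from compound 1 to compound 3 (0.21 log units; within the scatter); compound 3 therefore cannot be separated from either neighbour, although the earlier step, a 2.3-fold lower number from compound 1 to compound 2 (0.36 log units; beyond the scatter), does separate compound 1 from compound 2, and the three compounds form no clean graded order with the size of the group. No measurement here offers an explanation for these results.

On these data alone, all three side chains keep a hydroxyl group on a saturated chain, so it remains open whether an amine, a carboxylic acid or a plain propyl group at this nitrogen would move the number beyond the scatter. Also open are a chain longer than 1-ethyl-2-hydroxybutyl and the opposite configuration at the defined stereocentre, since each compound shown carries that centre in only one form.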